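Removing a Phenylsulfanyl Group from Compound 1

The source may hold more compounds than are shown below. What is called first, only, known or untested is meant among the compounds shown, and "the series" means these compounds.

Measured compounds:
compound 1, `CC1(Sc2ccccc2)C(=O)N(c2ccccc2)c2ncccc21`, gives 0%
compound 2, `CSc1ccc(N2C(=O)C(C)(C)c3cccnc32)cc1`, gives 37%
compound 3, `CC1(C)C(=O)N(c2cccc(Cl)c2)c2ncccc21`, gives 49%

All three were tested in a functional assay on the whole organism (Pleural cavity) for inhibition, with Rattus norvegicus as the target, at a dose of 25 mg/kg; on this read-out lower numbers stand for less inhibition and higher numbers for more inhibition at the one dose given (going by the name of the read-out). Compound 1 stands lowest of the three: compound 2 lies higher, beyond the usual scatter, and compound 3 lies higher still, also beyond the scatter. No two of the measured compounds differ in only one place, so no single change can be read off directly from these numbers.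

Compound 4, `CC1C(=O)N(c2ccccc2)c2ncccc21`, has not been measured. It differs from compound 1 in one place: hydrogen in place of phenylsulfanyl on a saturated ring carbon. Compounds 2 and 3 also lack a phenylsulfanyl group and show inhibition, but both carry two methyl groups on the saturated ring carbon where compound 4 carries one methyl and one hydrogen, so they do not settle the question.

Given that compound 1 gives 0% and cannot fall further, the step from compound 1 to compound 4 is expected to be upward, a number 20 percentage points higher from compound 1 to compound 4 (beyond the scatter), though it may well stay within the scatter. Compound 4 is estimated at 20% in this assay, most likely between 0% and 45%.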

Compound 4, a percentage reported as inhibition, in the whole organism at one dose (the size of the read-out at that dose, not a potency): 18%
Estimate against measurement, compound 4: 2 percentage points above, and the stated range covers the measured number.
By their numbers in this assay, from the lowest: compound 1; then compound 4; then compound 2; then compound 3.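

In this assay, putting hydrogen in place of phenylsulfanyl on the saturated ring carbon gives a number 18 percentage points higher from compound 1 to compound 4 (beyond the scatter). Among the compounds shown here, this is the first direct reading of this position, since the two compounds differ in that one place only and the change in the number can be tied to the swap of these two groups. The step shows that inhibition at this dose can be recovered on the core of compound 1 by removing the phenylsulfanyl group alone, without any other change to the structure, though nothing measured here explains why the number moves.

The compounds shown leave open how other groups would behave on this same saturated ring carbon, such as an amine, a carboxylic acid or a longer chain like propyl, and whether any of them would give a higher or a lower number than hydrogen does. They also leave open whether swapping phenylsulfanyl for hydrogen would give a step of similar size on a core whose phenyl group carries a chlorine or a methylsulfanyl group.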